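The compounds below may be only part of what the source reports. "The series", "measured", "known", "first", "only" and "open" are said of these compounds alone.

Measured compounds and values in a functional assay on UO-31 cells (Homo sapiens) for inhibition, read by sulforhodamine B assay, with a stated time of 48 h; on this read-out lower numbers stand for higher toxicity in this test and higher numbers for lower toxicity in this test:
compound 1 `Nc1cc(N)c2nc(-c3ccccc3)c(Oc3ccc(Cl)c(Cl)c3)nc2c1` — < 100000 nM
compound 2 `Nc1cc(N)c2nc(-c3ccccc3)c(Sc3ccc(Cl)c(Cl)c3)nc2c1` — < 100000 nM

In this assay compound 1 gives < 100000 nM, a limit of the assay rather than a number. Compound 2 likewise gives < 100000 nM, also a limit. Going by the values given here, the one measured step, a step that the two limits leave unreadable from compound 1 to compound 2, is therefore unreadable, and the limit of < 100000 nM in this assay, at which 2 of the 2 values shown sit, is all that holds. Compound 3 `Nc1cc(N)c2nc(-c3ccccc3)c(Oc3ccc(F)cc3)nc2c1` differs from compound 2 by 4-fluorophenoxy in place of (3,4-dichlorophenyl)sulfanyl on an aromatic carbon. Among the compounds with values here, no measured step bears on this change. Compound 3 is expected to stay at the same limit, an estimated step that the limit leaves unreadable from compound 2 to compound 3. The estimate for compound 3 is 50000 nM, within 10000 nM to 100000 nM.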

Compound 3, concentration lethal to 50% of the cells: < 100000 nM
Compound 3 gave a limit, no number; the forecaster's own chance of this, stated with the estimate: 60%; the middle value does not contradict the limit.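

Going by these compounds alone, compound 3 gives < 100000 nM, a limit of the assay and not a number, so no step among compound 1, compound 2 and compound 3 can be read. The compounds shown leave open where each of the three actually lies in this assay, and whether any of these changes matters there.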